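This account rests on a few compounds, and the source may have more. Where it says the series, first, only, none or still open, it means among the compounds named here.

Measured compounds:
compound 1 `CC(C)c1c(C(=O)N2CCCC2c2ccccc2)nn(-c2ccc(F)cc2)c1OC[C@@H](O)C[C@@H](O)CC(=O)O`, 14 nM
compound 2 `CC(C)c1c(C(=O)NCc2ccccc2Cl)nn(-c2ccc(F)cc2)c1OC[C@@H](O)C[C@@H](O)CC(=O)O`, 9.5 nM

Both were tested in an assay on microsomes from liver for inhibition of 3-hydroxy-3-methylglutaryl-coenzyme A reductase (Rattus norvegicus); a lower number here means a stronger inhibitor, a higher number a weaker inhibitor. For the measured compounds named here, compound 2 shows the lower of the two numbers, but the only step in the set, a 1.5-fold lower number from compound 1 to compound 2 (0.17 log units; within the scatter), lies within the scatter, so the two cannot be ordered. Compound 3 `COc1cccc(CN(C)C(=O)c2nn(-c3ccc(F)cc3)c(OC[C@@H](O)C[C@@H](O)CC(=O)O)c2C(C)C)c1` differs from compound 2 in one place: (3-methoxybenzyl)(methyl)amino in place of (2-chlorobenzyl)amino on a carbonyl carbon. Going by the values given here, the one step that bears on this change, the exchange of the amide substituent from compound 1 to compound 2, stayed within the scatter, so for compound 3 a step of a 1.3-fold higher number from compound 2 to compound 3 (0.10 log units; within the scatter) is expected, none beyond the scatter. Compound 3 is estimated at 12 nM in this assay, with a range of 5 nM to 30 nM.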

Compound 3, half-maximal inhibitory concentration: 21 nM
Compound 3: middle estimate off by 1.8-fold (0.24 log units), on the low side; measured number inside the range.
By their numbers in this assay, from the lowest: compounds 2, 1 and 3 (each within the scatter of the next, the first and the last beyond it).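

In this assay, for the compounds shown here, the exchange on the carbonyl carbon gives the first step beyond the scatter, though a modest one: a 2.2-fold higher number from compound 2 to compound 3 (0.34 log units; beyond the scatter). By contrast, a 1.5-fold higher number from compound 1 to compound 3 (0.18 log units; within the scatter) stays within the scatter, so this position shows a measurable difference only between compound 2 and compound 3. No available measurement accounts for this difference.

Going by these compounds, the change from compound 2 to compound 3 alters the amide hydrogen and the ring substituent together, so the contribution of each remains open. A (2-chlorobenzyl)(methyl)amino group on the same carbonyl carbon would separate the added methyl from the ring change.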